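The compounds below may be only part of what the source reports. "The series", "measured", "known", "first", "only" and "open" are said of these compounds alone.

Measured in an ADME assay on A549 cells (Homo sapiens) for cytotoxicity, read by LDH release, with a stated time of 15 h; a lower number here means that less compound is tolerated, a higher number that more compound is tolerated:

- compound 1 `CCCN(CCC)c1ccc(NC(=O)c2cc(Cl)ccc2O)c(Cl)c1`: 323000 nM
- compound 2 `O=C(Nc1ccc(NCC2CCCC2)cc1Cl)c1cc(Cl)ccc1O`: 141000 nM
- compound 3 `O=C(Nc1ccc(NCCCO)cc1Cl)c1cc(Cl)ccc1O`: "not determined" (no result reported)

Compound 3 has no number to start from, so it cannot anchor the next step. Compound 4 `CCCC(C)(C)Nc1ccc(NC(=O)c2cc(Cl)ccc2O)c(Cl)c1` keeps the shared core and changes only the group on the nitrogen: 1,1-dimethylbutyl in place of 3-hydroxypropyl on a nitrogen on an aromatic ring. Without a value for compound 3, no size or direction can be given for a step from it in this assay, and any expectation has to come from its two measured relatives. Within the data shown here, the only measured step is a 2.3-fold lower number from compound 1 to compound 2 (0.36 log units; beyond the scatter), a modest change that also replaces the group on that nitrogen, with (cyclopentylmethyl)amino taking the place of dipropylamino. The (1,1-dimethylbutyl)amino of compound 4 is closest to the amino group of compound 2, so the expectation leans on compound 2 at 141000 nM, while compound 1 at 323000 nM marks the upper part of the range. Two measured compounds are thin support, so the range stays wide. Compound 4 is expected at 160000 nM, with an estimated range of 65000 nM to 380000 nM.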

Compound 4, half-maximal cytotoxic concentration: 23700 nM
Estimate against measurement, compound 4: 6.8-fold (0.83 log units) above; measured number outside the range, below it.
By their numbers in this assay, from the lowest: compound 4; then compound 2; then compound 1.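

In this assay the group on the nitrogen moves the number further than the first measured step showed, with a 5.9-fold lower number from compound 2 to compound 4 (0.77 log units; beyond the scatter) when 1,1-dimethylbutyl replaces cyclopentylmethyl, and a 14-fold lower number from compound 1 to compound 4 (1.13 log units; beyond the scatter) when (1,1-dimethylbutyl)amino replaces dipropylamino. Both steps lie beyond the scatter, which leaves compound 4 as the least tolerated of the three compounds with a number, so the identity of this group matters to the read-out and not only its presence. Nothing measured here accounts for the drop.

From the compounds shown here alone, compound 3 has no number, so the step from it cannot be read and the standing of the 3-hydroxypropyl group remains unknown. Going by these compounds, it also remains open how a tert-butyl group, a shorter straight chain or a chain ending in a carboxylic acid on this nitrogen would compare.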